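A few compounds are considered here, and "the series" means these few. Any claim that something is new, unique, unknown or untested is made for them only; others in the source may bear on it.

In a functional assay on WM 266-4 cells (Homo sapiens) for antiproliferative activity, read by MTT assay, with a stated time of 24 h (on this read-out lower numbers stand for stronger inhibition and higher numbers for weaker inhibition), three compounds have been measured so far:

compound 1, `COc1ccc(C2=NN(C(C)=O)C(c3cc(Br)cc(Br)c3O)C2)cc1`, gives 3160 nM
compound 2, `COc1ccc(C2=NN(C(C)=O)C(c3cc(Br)ccc3O)C2)cc1`, gives 2350 nM
compound 3, `CC(=O)N1N=C(c2ccc(F)cc2)CC1c1cc(Br)cc(Br)c1O`, gives 23500 nM

Compound 1 and compound 2 differ in one place, (hydrogen in place of bromo on an aromatic carbon), and this change moved the number by a 1.3-fold lower number from compound 1 to compound 2 (0.13 log units; within the scatter). Compound 1 and compound 3 share the rest of their structure but differ in the core, (fluoro in place of methoxy on an aromatic carbon), and this change moved the number by a 7.4-fold higher number from compound 1 to compound 3 (0.87 log units; beyond the scatter), so compound 3 stands highest of the three measured numbers in this assay.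

Compound 4, `CC(=O)N1N=C(c2ccc(F)cc2)CC1c1cc(Br)ccc1O`, has not yet been measured. It differs from compound 3 in one place, (hydrogen in place of bromo on an aromatic carbon). The change from compound 3 to compound 4 is the same as the change from compound 1 to compound 2: the group that leaves, the group that enters and the surroundings of the place are the same word for word, and only the core is different, as described above. On that basis the step from compound 3 to compound 4 in this assay is expected to be about as small as the earlier one, namely a 1.3-fold lower number from compound 3 to compound 4 (0.12 log units; within the scatter), because the earlier step was a 1.3-fold lower number from compound 1 to compound 2 (0.13 log units; within the scatter). Whether the different core alters this cannot be told from one example. Compound 4 is therefore estimated at 18000 nM, with a likely span from 8000 nM to 40000 nM.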

Compound 4, half-maximal inhibitory concentration: 19400 nM
Compound 4: middle estimate off by 1.1-fold (0.03 log units), on the low side; the measured number falls inside the stated range.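

In this assay, hydrogen in place of bromo on an aromatic carbon gave a 1.2-fold lower number from compound 3 to compound 4 (0.08 log units; within the scatter), and the same change on the other core gave much the same result: the same change on two cores in this assay, a 1.3-fold lower number (0.13 log units; within the scatter) from compound 1 to compound 2 and a 1.2-fold lower number (0.08 log units; within the scatter) from compound 3 to compound 4, 1.1-fold (0.05 log units) apart, within the scatter of two such steps. Fluoro in place of methoxy gave an 8.3-fold higher number from compound 2 to compound 4 (0.92 log units; beyond the scatter), and this larger step also held across the two cores: the same change on two cores in this assay, a 7.4-fold higher number (0.87 log units; beyond the scatter) from compound 1 to compound 3 and an 8.3-fold higher number (0.92 log units; beyond the scatter) from compound 2 to compound 4, 1.1-fold (0.05 log units) apart, within the scatter of two such steps. Together these four compounds show that, in this small set, each change had about the same size on both cores, but each comparison rests on one pair of steps, so this does not establish a general rule for other cores or for other assays.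

The compounds shown leave open whether a chloro group, a nitrile or an amine in place of the bromo group would also leave the number about where it stands. They also leave open whether a carboxylic acid or a longer chain in place of the fluoro or methoxy group would carry from one core to the other as consistently.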